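A Methyl Comes Off: From Compound 2 to Compound 3

A few compounds are considered here, and "the series" means these few. Any claim that something is new, unique, unknown or untested is made for them only; others in the source may bear on it.

Compound 1, `CCn1nnc(-c2sc(-c3ccccc3O)nc2O)n1`, gives 24 nM.
Compound 2, `CCOC(=O)c1sc(-c2ccc(C)cc2)nc1O`, gives 160 nM.

Of the compounds shown here, two have been measured in an assay on HEK293 cells for inhibition of transient receptor potential cation channel subfamily M member 8 (Homo sapiens), read by FLIPR, with stated times of 5 min and 3 min; a higher number here means a weaker inhibitor, a lower number a stronger inhibitor. Compound 1 gives 24 nM and compound 2 gives 160 nM, so compound 2 stands with the higher of the two numbers, and the gap to compound 1 lies beyond the usual scatter. Within the data shown here, the two structures differ in more than one place, and no single step between them has been recorded, so only the two values themselves can be compared.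

The step under study leads from compound 2 to compound 3, `CCOC(=O)c1sc(-c2ccccc2)nc1O`, which is not yet measured in this assay. The change is small: hydrogen in place of methyl on an aromatic carbon, the change sitting on an aromatic carbon of a six-membered aromatic ring of carbon only, para to a large group. With nothing measured on either side of this change, the expectation rests on the size of the change alone. The author expects a step of a 1.6-fold higher number from compound 2 to compound 3 (0.19 log units; within the scatter) in this assay, towards a somewhat higher number, though likely within or near the scatter. For compound 3 the estimate in this assay is 250 nM, between 100 nM and 700 nM.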

Compound 3, half-maximal inhibitory concentration: 32 nM
Compound 3: middle estimate off by 7.8-fold (0.89 log units), on the high side; measured number outside the range, below it.
By their numbers in this assay, from the lowest: compounds 1 and 3 (each within the scatter of the next); then compound 2.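

Hydrogen in place of methyl gives a 5.0-fold lower number from compound 2 to compound 3 (0.70 log units; beyond the scatter) in this assay and is the first step here between compounds that differ in one place. It shows that this position, on an aromatic carbon of a six-membered aromatic ring of carbon only, para to a large group, is not indifferent to small changes: the loss of a single carbon, with no ring, hydrogen-bond donor, hydrogen-bond acceptor or net charge leaving or entering, moves the number beyond the scatter, towards a stronger inhibitor. Nothing available accounts for the size or direction of this step.

Going by these compounds, a single step cannot tell whether hydrogen is the best choice at this place, so it remains open how fluorine, chlorine, methoxy or a longer chain such as ethyl there would read in this assay and whether any would match hydrogen. Also open, on these data alone, is whether the step would hold with the ethyl ester replaced by a carboxylic acid or an amide, since every comparison so far rests on this one pair.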